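Solubility notes: acetyl to tert-butyl amide

The compounds below may be only part of what the source reports. "The series", "measured", "known", "first", "only" and "open" are said of these compounds alone.

Measured so far in a physicochemical assay for solubility; a lower number here means a less soluble compound, a higher number a more soluble compound
compound 1 (`O=C(CN1CCNCC1)N1CCC(NS(=O)(=O)c2cc(S(=O)(=O)c3ccccc3)ccc2C(F)(F)F)CC1`) gives 50000 nM
compound 2 (`O=C1CC[C@@H](C(=O)N2CCC(NS(=O)(=O)c3cc(S(=O)(=O)c4ccccc4)ccc3C(F)(F)F)CC2)N1`) gives 100000 nM
compound 3 (`CC(=O)N1CCC[C@H]1C(=O)N1CCC(NS(=O)(=O)c2cc(S(=O)(=O)c3ccccc3)ccc2C(F)(F)F)CC1`) gives 12500 nM

Compound 3 stands lowest of the three, beyond the scatter from both others. Compound 4 (`CC(C)(C)C(=O)N1CCC[C@H]1C(=O)N1CCC(NS(=O)(=O)c2cc(S(=O)(=O)c3ccccc3)ccc2C(F)(F)F)CC1`) has tert-butyl in place of methyl on a carbonyl carbon. Going by the values given here, no measured step alters this group directly. The closest evidence is two modest downward steps (a 4.0-fold lower number from compound 1 to compound 3 (0.60 log units; beyond the scatter)) and (an 8.0-fold lower number from compound 2 to compound 3 (0.90 log units; beyond the scatter)), which support the direction only indirectly. A further modest fall in this assay is expected, of about the size of the smaller step. The expected step is a 2.5-fold lower number from compound 3 to compound 4 (0.40 log units; beyond the scatter) and it remains uncertain. For compound 4 the estimated value is 5000 nM with an expected range of 1500 nM to 12500 nM in this assay.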

Compound 4, solubility: 50000 nM
Compound 4: middle estimate off by 10-fold (1.00 log units), on the low side; measured number outside the range, above it.
By their numbers in this assay, from the lowest: compound 3; then compounds 1, 4 and 2 (each within the scatter of the next).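

In this assay, the group on this carbonyl carbon matters: tert-butyl in place of methyl gives (a 4.0-fold higher number from compound 3 to compound 4 (0.60 log units; beyond the scatter)), so the low number of compound 3 does not carry over to the 1-((tert-butyl)carbonyl)pyrrolidin-2-yl group. That group also stays within the scatter of the other two groups (a 2.0-fold lower number from compound 2 to compound 4 (0.30 log units; within the scatter); no change at the digits printed from compound 1 to compound 4 (within the scatter)). Nothing available accounts for this rise.

Going by these compounds, it remains open whether ethyl or isopropyl on this carbonyl carbon would track methyl or tert-butyl in this assay. An amine-bearing chain at the same place is also an open case.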